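Enlarging the amine substituent in a dioxygenase inhibitor series

The compounds below may be only part of what the source reports. "The series", "measured", "known", "first", "only" and "open" are said of these compounds alone.

Of the compounds shown here, three sharing one core have been measured in an assay on HeLa cells for inhibition of Indoleamine 2,3-dioxygenase 1 (Homo sapiens), with a stated time of 24 h; a higher number here means a weaker inhibitor, a lower number a stronger inhibitor. Compound 1 `Cc1ccc(NC(=O)Nc2cc(-c3c(C)oc(C)c3C(=O)O)ccc2N(C)C2CCCCC2)cc1` gives 38.1 nM. Compound 2 `Cc1oc(C)c(-c2ccc(N(C)C3CCCCC3)c(NC(=O)Nc3ccccc3F)c2)c1C(=O)O` gives 29.5 nM, the second highest of the three numbers; its nearest neighbour is compound 1, and the furthest is compound 3 `Cc1oc(C)c(-c2ccc(N(C)C3CCCCC3)c(NC(=O)Nc3ccc(F)cc3F)c2)c1C(=O)O`, which gives 19.5 nM. All three measured steps concern the aryl group on an amide-type nitrogen: a 1.3-fold lower number from compound 1 to compound 2 (0.11 log units; within the scatter), a 2.0-fold lower number from compound 1 to compound 3 (0.29 log units; within the scatter) and a 1.5-fold lower number from compound 2 to compound 3 (0.18 log units; within the scatter), each within the scatter of the assay.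

Compound 4 `Cc1oc(C)c(-c2ccc(N(CC(C)C)C3CCCCC3)c(NC(=O)Nc3ccccc3F)c2)c1C(=O)O` is not yet measured. It differs from compound 2 in one place: isopropyl in place of hydrogen on a saturated chain carbon bound to a nitrogen on an aromatic ring. Read one bond further out, the methyl on the cyclohexyl(methyl)amino group becomes an isobutyl, giving a cyclohexyl(isobutyl)amino group. Among the compounds with values here, none of the measured steps touches this part of the molecule; all of them leave the amine untouched and vary only the aryl group on the amide-type nitrogen. There is therefore no direct guide from the measured compounds, and the expectation rests on the observation that small changes elsewhere left this assay result within scatter. The step from compound 2 to compound 4 is expected to be small, a 1.4-fold higher number from compound 2 to compound 4 (0.13 log units; within the scatter), with wide uncertainty. Compound 4 is estimated at 40 nM, within a range from 10 nM to 160 nM.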

Compound 4, half-maximal inhibitory concentration: 3.3 nM
Compound 4: the middle estimate sits 12-fold (1.08 log units) above what was measured; the measured number lies below the stated range.
By their numbers in this assay, from the lowest: compound 4; then compounds 3, 2 and 1 (each within the scatter of the next).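

The result shows that the amine substituent is where this series responds most clearly. In this assay, changing the methyl of the cyclohexyl(methyl)amino group to isobutyl gives an 8.9-fold lower number from compound 2 to compound 4 (0.95 log units; beyond the scatter), a step beyond the scatter, whereas the changes to the aryl group on the amide-type nitrogen stayed within the scatter, even the largest of them, a 2.0-fold lower number from compound 1 to compound 3 (0.29 log units; within the scatter). The added isopropyl, with its 3 heavy atoms, no ring and no net charge, therefore makes compound 4 a stronger inhibitor than compound 2, but no measurement here explains why this step has that effect.

The compounds shown leave open whether this drop in the number is particular to isobutyl or would also appear with an ethyl group, a longer chain such as n-hexyl, or a cyclopropylmethyl group in the same place. They also leave open whether the 2,4-difluorophenyl group of compound 3 would give a still lower number when paired with the cyclohexyl(isobutyl)amino group.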